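Benzyl Traded for Isopropyl on One Ester Oxygen

The source may hold more compounds than are shown below. What is called first, only, known or untested is meant among the compounds shown, and "the series" means these compounds.

Three measured compounds share one core and differ in their ester groups. Compound 1 `COCCOC(=O)C1=C(C)NC(C)=C(C(=O)OCCOC)C1c1cnc(SC)n1Nc1ccccc1` gives 17.9 nM in an assay on isolated protein (strain albino) for antagonist activity at Voltage-dependent L-type calcium channel subunit alpha-1C (Cavia porcellus); on this read-out higher numbers stand for weaker inhibition and lower numbers for stronger inhibition. Compound 2 `CSc1ncc(C2C(C(=O)OC3CCCCC3)=C(C)NC(C)=C2C(=O)OC2CCCCC2)n1Nc1ccccc1` gives 465 nM in this assay. Compound 3 `CSc1ncc(C2C(C(=O)OCc3ccccc3)=C(C)NC(C)=C2C(=O)OCc2ccccc2)n1Nc1ccccc1` gives 1.49 nM in this assay, the lowest number of the three; compound 1 stands nearest, with a higher number that lies beyond the usual scatter, and compound 2 stands furthest, with a much higher number, also beyond the scatter.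

Compound 4 `CSc1ncc(C2C(C(=O)OCc3ccccc3)=C(C)NC(C)=C2C(=O)OC(C)C)n1Nc1ccccc1` has not yet been measured. It differs from compound 3 in one place: isopropyl in place of benzyl on an oxygen next to a carbonyl group. Within the data shown here, no measured pair shows this exact change, and only one of the two benzyl groups is exchanged. Both compounds without benzyl groups, compound 1 and compound 2, give higher numbers than compound 3, so the expected step from compound 3 to compound 4 in this assay is a rise, a 3.4-fold higher number from compound 3 to compound 4 (0.53 log units; beyond the scatter), probably just beyond the scatter. Compound 4 is therefore estimated at 5 nM, with a range from 1.5 nM to 20 nM.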

Compound 4, half-maximal inhibitory concentration: 7.24 nM
Compound 4: middle estimate off by 1.4-fold (0.16 log units), on the low side, within the range that was stated.
By their numbers in this assay, from the lowest: compound 3; then compound 4; then compound 1; then compound 2.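

In this assay, among these compounds, this is the first direct reading of the change on a single ester: a 4.9-fold higher number from compound 3 to compound 4 (0.69 log units; beyond the scatter), when isopropyl stands in place of benzyl on an oxygen next to a carbonyl group. The step lies beyond the usual scatter, yet it is modest, and it shows that one benzyl group can leave while the other stays and compound 4 still gives a low number of 7.24 nM. Nothing available here explains why the number rises with this exchange.

The compounds shown leave open whether the benzyl group that remains in compound 4 would give a similar step if it were exchanged for isopropyl as well. They also leave open how the number would move with an ethyl group or a chain ending in an amine on this same oxygen.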